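Swapping an Amide for a Sulfonamide: What Compound 4 Might Show

The compounds below may be only part of what the source reports. "The series", "measured", "known", "first", "only" and "open" are said of these compounds alone.

Compound 1, `CCn1cc(Nc2ccn3ncc(-c4ccc(OC)cc4)c3n2)cn1`: in an assay on isolated protein for inhibition of eIF-2-alpha kinase GCN2 (Homo sapiens) (a higher number here means a weaker inhibitor, a lower number a stronger inhibitor), compound 1 reaches only the limit > 1000 nM.
Compound 2, `CCn1cc(Nc2ncc3c(C)nn(-c4ccc(OC)cc4)c3n2)cn1`: in this assay compound 2 gives 81 nM.
Compound 3, `COCCC(=O)N[C@@H]1CC[C@@H](Nc2ncc3c(Br)nn(-c4ccc5ncccc5c4)c3n2)C1`: in this assay compound 3 gives 74 nM.

For compound 1 the read-out is the limit of > 1000 nM in this assay, at which 1 of the 3 values shown sits, a limit of the assay rather than a number. Of the two numbers, compound 3 gives the lower one, but its gap to compound 2 lies within the scatter, so neither of the two can be called the stronger inhibitor on these data.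

Compound 4, `COCCS(=O)(=O)N[C@@H]1CC[C@@H](Nc2ncc3c(Br)nn(-c4ccc5ncccc5c4)c3n2)C1`, has not yet been measured. It differs from compound 3 in one place: (2-methoxyethyl)sulfonyl in place of (2-methoxyethyl)carbonyl on an amine nitrogen. For the measured compounds named here, no pair of measured compounds shows this change, so there is no measured step to lean on. The expectation is for no step beyond the scatter, leaning if at all toward a slightly higher number. Compound 4 is expected to give 110 nM, with a range from 40 nM to 350 nM. That corresponds to an expected step of a 1.5-fold higher number from compound 3 to compound 4 (0.17 log units; within the scatter).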

Compound 4, half-maximal inhibitory concentration: 55 nM
For compound 4 the middle estimate is 2.0-fold (0.30 log units) above the measured one; the range from low to high includes it.
By their numbers in this assay, from the lowest: compounds 4, 3 and 2 (each within the scatter of the next). At a limit, above all of these: compound 1.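

Putting (2-methoxyethyl)sulfonyl in place of (2-methoxyethyl)carbonyl on an amine nitrogen gives a 1.3-fold lower number from compound 3 to compound 4 (0.13 log units; within the scatter) in this assay. For the compounds shown here, this is the only measured step at this position, and it shows that the change leaves compound 3 and compound 4 indistinguishable on this read-out, which the earlier compounds, with no pair differing in one place, could not show. Nothing measured here accounts for this result.

Going by these compounds, whether the same holds with a methylsulfonyl group, a urea or a free amine on this nitrogen remains open. So does whether the change would read the same on the core of compound 2, since this single pair speaks only for the core shared by compound 3 and compound 4.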